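The compounds below may be only part of what the source reports. "The series", "measured", "known", "first", "only" and "open" are said of these compounds alone.

Measured compounds:
compound 1 `COc1ccc(CS(=O)(=O)/C=C/c2ccc(C)cc2C)cc1` — 15000 nM
compound 2 `COc1ccc(CS(=O)(=O)/C=C/c2c(C)cccc2C)cc1` — > 20000 nM

In a functional assay on DLD-1 cells (Homo sapiens) for antiproliferative activity, read by trypan blue exclusion (on this read-out higher numbers stand for weaker inhibition and lower numbers for stronger inhibition), compound 1 gives 15000 nM. For compound 2 the assay gives only a limit, > 20000 nM, and not a number. This is the limit of > 20000 nM in this assay, at which 1 of the 2 values shown sits, so where compound 2 stands on the numbers shown cannot be placed more closely than that limit. Compound 3 `COc1ccc(CS(=O)(=O)/C=C/c2c(C)cc(C)cc2C)cc1` has not yet been measured in this assay. It differs from compound 2 by methyl in place of hydrogen on an aromatic carbon. No step between two measured compounds is shown here, so there is no measured guide to the size of such a change. Given that compound 2 gives only a limit, the step is expected to be a step that the limit leaves unreadable from compound 2 to compound 3, none beyond the scatter. Compound 3 is therefore estimated at 25000 nM, with a range from 8000 nM to 80000 nM, and a limit is again likely.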

Compound 3, half-maximal inhibitory concentration: > 20000 nM
Compound 3: a limit, no number; the forecaster's own chance of this, stated with the estimate: 70%; the middle value does not contradict the limit.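

Compound 3 also gives only a limit in this assay, > 20000 nM, and not a number. Against compound 1, which differs by the same kind of change, the methyl in place of hydrogen gives an at least 1.3-fold higher number from compound 1 to compound 3 (0.12 log units; that floor lies within the scatter), so the added methyl brings no sign of stronger inhibition, though this reading does not separate the two compounds. The step between compound 2 and compound 3, with the methyl on the aromatic carbon para to a large group, cannot be read: the limit of > 20000 nM in this assay, at which 2 of the 3 values shown sit.

Going by these compounds, it stays open how far beyond the limit compound 2 and compound 3 lie, so any effect of this methyl on them remains hidden. On these data alone, it is also open whether another group at this position, such as an amine or a carboxylic acid, would give a number in this assay rather than a limit.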